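The source may hold more compounds than are shown below. What is called first, only, known or untested is meant among the compounds shown, and "the series" means these compounds.

Measured so far:
compound 1 `COc1ccc(CCC(C)(C)C)c(N2CCC(COc3cccc(C(CC(=O)O)C4CC4)c3)CC2)c1`: 110%
compound 2 `COc1ccc(CCC(C)(C)O)c(N2CCC(COc3cccc(C(CC(=O)O)C4CC4)c3)CC2)c1`: 109%

In a functional assay on cells for agonist activity at Free fatty acid receptor 1 (Homo sapiens), read by FLIPR and calcium flux, with a stated time of 60 min (on this read-out higher numbers stand for larger maximal responses and lower numbers for smaller maximal responses), compound 1 reaches 110%, and in this assay compound 2 reaches 109%. Within the data shown here, compound 2 holds the lower of the two numbers, but the only measured step, a number 1 percentage points lower from compound 1 to compound 2 (within the scatter), lies within the scatter, so the two compounds cannot be ordered on this read-out.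

Compound 3 `COc1ccc(CN(C)CC(C)C)c(N2CCC(COc3cccc(C(CC(=O)O)C4CC4)c3)CC2)c1` is not yet measured. It differs from compound 2 by isobutyl(methyl)amino in place of 2-hydroxy-2-methylpropyl on a saturated chain carbon bound to an aromatic carbon. Among the measured compounds shown here, the one measured step concerns a hydroxy in place of a methyl on a saturated chain carbon and gave a change within the scatter; it does not touch the saturated chain carbon bound to an aromatic carbon that is altered here, so no measured step bears directly on this exchange. With both measured compounds giving full maximal responses, the step of a number 9 percentage points lower from compound 2 to compound 3 (within the scatter) is expected to stay within the scatter, though a loss cannot be ruled out. Compound 3 is therefore estimated at 100%, with a range from 70% to 120%.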

Compound 3, largest response reached (Emax), in percent of the reference or control that the assay uses: 110%
Estimate against measurement, compound 3: 10 percentage points below, within the range that was stated.
By their numbers in this assay, from the lowest: compounds 2, 1 and 3 (each within the scatter of the next).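

In this assay, isobutyl(methyl)amino in place of 2-hydroxy-2-methylpropyl on a saturated chain carbon bound to an aromatic carbon gives a number 1 percentage points higher from compound 2 to compound 3 (within the scatter), and the same group in place of neopentyl gives no change at the digits printed from compound 1 to compound 3 (within the scatter). The earlier compounds shown here differed only by a hydroxy in place of a methyl, whereas compound 3 carries a group with a nitrogen and 0 hydrogen-bond donors at this place, and the maximal response does not separate it from either compound 1 or compound 2. Nothing given here accounts for this outcome.

The compounds shown leave open whether a primary amine, an amide or a longer chain at this place would also give a maximal response within the scatter of these three. They also leave open how the three compare on potency, since only the maximal response is shown.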